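The source may report more compounds than this note shows. Statements on the series, on what has been measured and on what is new or still open speak of the compounds shown alone.

Measured so far:
- compound 1 `CC(=NNC(=S)Nc1ccccc1F)c1ccccn1`: 0.39 nM
- compound 2 `C/C(=N\NC(=S)Nc1ccccc1Cl)c1ccccn1`: 0.16 nM

In a functional assay on MCF7 cells (Homo sapiens) for cytotoxicity, read by MTT assay, with a stated time of 48 h (on this read-out lower numbers stand for stronger inhibition and higher numbers for weaker inhibition), compound 2 gives 0.16 nM, the lower of the two numbers, and its gap to compound 1 lies beyond the scatter. Compound 3 `C/C(=N\NC(=S)Nc1ccccc1F)c1ccccn1`, not yet measured, has fluoro in place of chloro on an aromatic carbon. For the measured compounds named here, the expectation rests on the only fluoro value at hand, compound 1 at 0.39 nM. A modest rise in the number is expected in this assay, near the edge of the scatter: a 2.3-fold higher number from compound 2 to compound 3 (0.35 log units; beyond the scatter). Compound 3 is estimated at 0.36 nM, with an expected range of 0.13 nM to 1 nM.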

Compound 3, half-maximal inhibitory concentration: 0.39 nM
Beside the measured number, compound 3's estimate is 1.1-fold (0.03 log units) below it; measured number inside the range.
By their numbers in this assay, from the lowest: compound 2; then compounds 1 and 3 (each within the scatter of the next).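

In this assay, the place on the aromatic carbon ortho to a large group now has a single-change comparison: fluoro in place of chloro gives a 2.4-fold higher number from compound 2 to compound 3 (0.39 log units; beyond the scatter), so at this place the chloro compound has the lower number. The drawn double-bond configuration shows no separation, with no change at the digits printed from compound 1 to compound 3 (within the scatter). That comparison has a limit in how it can be read: the fact that one of compounds 1 and 3 is drawn with a defined configuration and the other without, at the place where they differ

Only chloro and fluoro are compared at this place. From the compounds shown here alone, how bromo, a methoxy group or an amine would read there remains open.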